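Sulfur substituent swap in a propanamide antagonist series

This account rests on a few compounds, and the source may have more. Where it says the series, first, only, none or still open, it means among the compounds named here.

Measured compounds:
compound 1 `CCCCCSc1nc(C(F)(F)F)ccc1CNC(=O)C(C)c1ccc(NS(C)(=O)=O)c(F)c1`, 2.5 nM
compound 2 `CC(C(=O)NCc1ccc(C(F)(F)F)nc1SCCOc1ccccc1)c1ccc(NS(C)(=O)=O)c(F)c1`, 2.3 nM
compound 3 `CC(C(=O)NCc1ccc(C(F)(F)F)nc1SCCC(=O)N1CCCC1)c1ccc(NS(C)(=O)=O)c(F)c1`, 85 nM

All three share one core and differ only in the group attached through sulfur. In an assay on CHO-K1 cells for antagonist activity at transient receptor potential cation channel subfamily V member 1 (Homo sapiens), read by FLIPR (on this read-out higher numbers stand for weaker inhibition and lower numbers for stronger inhibition), compound 3 gives the highest number of the three: a 34-fold higher number from compound 1 to compound 3 (1.53 log units; beyond the scatter) and a 37-fold higher number from compound 2 to compound 3 (1.57 log units; beyond the scatter), both large and well beyond the scatter. Compound 1 and compound 2, by contrast, sit together, since a 1.1-fold lower number from compound 1 to compound 2 (0.04 log units; within the scatter).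

Compound 4 `CC1CCC(Sc2nc(C(F)(F)F)ccc2CNC(=O)C(C)c2ccc(NS(C)(=O)=O)c(F)c2)CC1` is not yet measured. Its difference from compound 3 is 4-methylcyclohexyl in place of 2-((pyrrolidin-1-yl)carbonyl)ethyl on a sulfur. The entering group carries no hydrogen-bond acceptor, which puts compound 4 closer to compound 1 and compound 2 than to compound 3; in the measured steps, the only chain that carries a carbonyl belongs to compound 3, and that compound stands apart from the other two.

The two large steps therefore bear directly on this change, and the expectation in this assay is a large drop back toward the numbers of compound 1 and compound 2, i.e. a 21-fold lower number from compound 3 to compound 4 (1.33 log units; beyond the scatter) is expected. For the measured compounds named here, for compound 4 the estimated value is 4 nM, with a range from 1 nM to 20 nM; the uncertainty is wider than usual because a ring on the sulfur has no measured precedent in this set.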

Compound 4, inhibition constant: 0.5 nM
The estimate for compound 4 lay 8.0-fold (0.90 log units) above the measured number, and the stated range ends above it.
By their numbers in this assay, from the lowest: compound 4; then compounds 2 and 1 (each within the scatter of the next); then compound 3.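

In this assay, the sulfur position now proves able to go below the level shared by the open-chain groups: besides a 170-fold lower number from compound 3 to compound 4 (2.23 log units; beyond the scatter), 4-methylcyclohexyl gives a 4.6-fold lower number from compound 2 to compound 4 (0.66 log units; beyond the scatter) in place of 2-phenoxyethyl and a 5.0-fold lower number from compound 1 to compound 4 (0.70 log units; beyond the scatter) in place of pentyl, both modest but beyond the scatter. For the compounds shown here, the earlier compounds showed only that pentyl and 2-phenoxyethyl could not be told apart and that 2-((pyrrolidin-1-yl)carbonyl)ethyl stood far above them, so a group's size and shape at this sulfur can now be seen to matter even among groups without a carbonyl, and compound 3 remains the only one of the four that carries a carbonyl and the only one with a number this high. No measurement shown here accounts for the difference between the ring and the chains.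

The compounds shown leave open whether the gain belongs to the cyclohexyl ring or to its methyl group, which a plain cyclohexyl or a cyclopentyl on the sulfur would help to separate. They also leave open whether the carbonyl or the pyrrolidine ring goes with the high number of compound 3, a question that an amine such as 2-(pyrrolidin-1-yl)ethyl on the sulfur would address.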